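Anilinoquinazoline-type thioethers on breast cancer cells: a nitro swap

A few compounds are considered here, and "the series" means these few. Any claim that something is new, unique, unknown or untested is made for them only; others in the source may bear on it.

Measured so far:
compound 1 `CCOc1ccccc1Nc1nc(SCc2ccc(C(F)(F)F)cc2)nc2ccccc12` — > 50000 nM
compound 2 `Cc1ccccc1Nc1nc(SCc2ccc(C(F)(F)F)cc2)nc2ccccc12` — 37500 nM

In a functional assay on MCF7 cells (Homo sapiens) for cytotoxicity, read by MTT assay, with a stated time of 72 h (on this read-out lower numbers stand for stronger inhibition and higher numbers for weaker inhibition), compound 2 gives 37500 nM, the only plain number shown. For compound 1 the result is a limit rather than a number, > 50000 nM; this is the limit of > 50000 nM in this assay, at which 1 of the 2 values shown sits. Going by the values given here, the one measured step, an at least 1.3-fold lower number from compound 1 to compound 2 (0.12 log units; that floor lies within the scatter), therefore has a floor that lies within the scatter and says little.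

Compound 3 `O=[N+]([O-])c1cccc(Nc2nc(SCc3ccc(C(F)(F)F)cc3)nc3ccccc23)c1` changes compound 2 by 3-nitrophenyl in place of 2-methylphenyl on a nitrogen on an aromatic ring. Among the compounds with values here, no measured step covers this change; the step from compound 1 to compound 2 touches the same aromatic ring on the nitrogen but does not reach beyond the scatter. Nothing in the data points to a gain or a loss, so no movement beyond the scatter is expected, and the step of a 1.1-fold lower number from compound 2 to compound 3 (0.03 log units; within the scatter) is estimated accordingly. Compound 3 is expected at 35000 nM, with a range from 10000 nM to 100000 nM.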

Compound 3, half-maximal inhibitory concentration: > 50000 nM
Compound 3: a limit, no number; the forecaster's own chance of this, stated with the estimate: 40%; middle value at least 1.4-fold (0.15 log units) from the limit.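

Putting 3-nitrophenyl in place of 2-methylphenyl on the nitrogen brings no sign of a gain: in this assay compound 3 gives > 50000 nM, which is a limit and not a number. The change amounts to an at least 1.3-fold higher number from compound 2 to compound 3 (0.12 log units; that floor lies within the scatter), so no true loss can be claimed either. The step joining compound 1 and compound 3 cannot be read, and two quite different groups on this aromatic ring have now ended at the same ceiling: the limit of > 50000 nM in this assay, at which 2 of the 3 values shown sit.

Going by these compounds, how far compound 3 really lies from compound 2 stays open, since only a plain number for compound 3 could settle it. Also open, on these data alone, is whether any group on this ring can give a clear gain, for example an amine or a carboxylic acid in place of the nitro group.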